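The compounds below may be only part of what the source reports. "The series", "measured", "known", "first", "only" and "open" are said of these compounds alone.

Compounds measured so far:
- Compound 1 `O=C1C2=C(C(=O)c3ncccc31)C1(CS2)NC(=O)N(c2ccc(Cl)cc2)C1=O` gives 10 nM in a functional assay on CCRF-CEM cells (Homo sapiens) for antiproliferative activity, read by MTT assay, with a stated time of 96 h; a higher number here means a weaker inhibitor, a lower number a stronger inhibitor.
- Compound 2 `CCN(CC)c1ccc(N2C(=O)NC3(CSC4=C3C(=O)c3ncccc3C4=O)C2=O)cc1` gives 20 nM in this assay.
- Compound 3 `CCc1ccc(N2C(=O)NC3(CSC4=C3C(=O)c3ncccc3C4=O)C2=O)cc1` gives 10 nM in this assay.

Compound 2 stands close to both neighbours: a 2.0-fold higher number from compound 1 to compound 2 (0.30 log units; within the scatter) and a 2.0-fold lower number from compound 2 to compound 3 (0.30 log units; within the scatter) are each within the scatter, so the three compounds are not separable on these numbers. Compound 4 `CN(C)c1ccc(N2C(=O)NC3(CSC4=C3C(=O)c3ncccc3C4=O)C2=O)cc1` arises from compound 2 by dimethylamino in place of diethylamino on an aromatic carbon. The bearing steps are a 2.0-fold higher number from compound 1 to compound 2 (0.30 log units; within the scatter) and a 2.0-fold lower number from compound 2 to compound 3 (0.30 log units; within the scatter), which show that exchanging the group on this aromatic carbon has so far moved nothing beyond the scatter. Compound 4 is therefore expected to show no step beyond the scatter, a 1.3-fold lower number from compound 2 to compound 4 (0.12 log units; within the scatter), and its value in this assay is estimated at 15 nM, between 6 nM and 40 nM.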

Compound 4, half-maximal inhibitory concentration: 1 nM
Compound 4: the middle estimate sits 15-fold (1.18 log units) above what was measured; the measured number lies below the stated range.
By their numbers in this assay, from the lowest: compound 4; then compounds 1, 3 and 2 (each within the scatter of the next).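

Exchanges on this aromatic carbon, para to a large group, had stayed within the scatter, but in this assay dimethylamino stands apart from all three other groups (a 20-fold lower number from compound 2 to compound 4 (1.30 log units; beyond the scatter); a 10-fold lower number from compound 3 to compound 4 (1.00 log units; beyond the scatter); a 10-fold lower number from compound 1 to compound 4 (1.00 log units; beyond the scatter)). Compound 2 also carries an amino nitrogen here, so the nitrogen alone does not go with the lower number; diethylamino and dimethylamino differ sharply. Nothing available explains this difference.

The compounds shown leave open whether methylamino or a ring amine such as pyrrolidine on this carbon would match compound 4 at 1 nM in this assay.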